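The source may hold more compounds than are shown below. What is called first, only, known or untested is meant among the compounds shown, and "the series" means these compounds.

Measured so far in a functional assay for agonist activity at G protein-coupled receptor 88 (Homo sapiens), read by HTRF and cAMP accumulation; a higher number here means that more compound is needed for the effect, a lower number that less compound is needed:
- Compound 1, `CC(C)CCNCCN(C(=O)[C@@H]1C[C@H]1c1ccccc1)c1ccc(-c2ccccc2)cc1`, gives 5.1 nM.
- Compound 2, `CC[C@H](C)[C@H](N)CN(C(=O)[C@@H]1C[C@H]1c1ccccn1)c1ccc(-c2ccccc2)cc1`, gives 130 nM.
- Compound 3, `CCCc1ccc(-c2ccc(N(C[C@@H](N)[C@@H](C)CC)C(=O)[C@@H]3C[C@H]3c3ccccc3)cc2)cc1`, gives 61 nM.

Among these three numbers compound 3 holds the second highest. Its nearest neighbour is compound 2, whose number is higher by an amount beyond the usual scatter, and its furthest is compound 1, whose number is lower by a margin well beyond the scatter. All three compounds share the same core, with the amide, the cyclopropane and the biphenyl attached in the same way; they differ in the amine chain, in the ring on the cyclopropane and in what sits on the far phenyl ring.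

The next compound, compound 4, `CC[C@H](C)[C@H](N)CN(C(=O)[C@@H]1C[C@H]1c1ccccc1)c1ccc(-c2ccc(OC)cc2)cc1`, keeps everything of compound 3 except one substituent on the far ring: methoxy in place of propyl on an aromatic carbon. Within the data shown here, no measured pair in this set isolates that change, so its effect can only be estimated. Because compound 3 stands at 61 nM, the expectation is a small step in this assay, not clearly in either direction, the move from compound 3 to compound 4 being estimated at a 1.4-fold lower number from compound 3 to compound 4 (0.13 log units; within the scatter). Compound 4 is therefore expected to give about 45 nM, within a range from 12 nM to 170 nM.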

Compound 4, half-maximal effective concentration: 120 nM
For compound 4 the middle estimate is 2.7-fold (0.43 log units) below the measured one; the range from low to high includes it.
By their numbers in this assay, from the lowest: compound 1; then compounds 3, 4 and 2 (each within the scatter of the next, the first and the last beyond it).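

Among these compounds, compound 3 and compound 4 are the first pair here that differs in one place only, so the group on the far ring can now be read directly in this assay. Methoxy in place of propyl gives a 2.0-fold higher number from compound 3 to compound 4 (0.29 log units; within the scatter), so at this position, para to a large group, exchanging the all-carbon chain for a group with one hydrogen-bond acceptor makes no difference that can be told from the scatter. As far as these compounds go, compound 1 and compound 2 have no group at this position, but they also differ from compound 3 and compound 4 elsewhere, so whether a group is needed here at all stays open. From the compounds shown here alone, what a carboxylic acid, an amine or a longer chain would do at this position is also open. No measurement shown here offers an explanation for this result.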